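Chloro Added to the Fused Ring of Compound 1

The compounds below may be only part of what the source reports. "The series", "measured", "known", "first", "only" and "open" are said of these compounds alone.

Measured compounds:
compound 1, `CCC1(CCCCN2CCN(c3ccc(Cl)cc3)CC2)C(=O)Nc2cc(F)ccc21` — 215 nM
compound 2, `CCC1(CCCCN2CCN(c3cccc(Cl)c3)CC2)C(=O)Nc2ccccc21` — 31 nM
compound 3, `CCC1(CCCCN2CCN(c3ccc(Cl)cc3)CC2)C(=O)Nc2ccccc21` — 93 nM

Of the compounds shown here, three sharing one core have been measured in an assay on membranes from frontal cortex for displacement of a labelled ligand from Adrenergic receptor alpha-1 (Rattus norvegicus), read by scintillation counting, with a stated time of 45 min; on this read-out lower numbers stand for stronger inhibition and higher numbers for weaker inhibition. Compound 1 gives the highest of the three numbers; its nearest neighbour is compound 3, reached by a 2.3-fold lower number from compound 1 to compound 3 (0.36 log units; beyond the scatter), and the furthest is compound 2, whose value stands well lower. Between compound 2 and compound 3 the step is a 3.0-fold higher number from compound 2 to compound 3 (0.48 log units; beyond the scatter).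

Compound 4, `CCC1(CCCCN2CCN(c3ccc(Cl)cc3)CC2)C(=O)Nc2cc(F)c(Cl)cc21`, differs from compound 1 by chloro in place of hydrogen on an aromatic carbon. The measured steps touch this change only from the side: the step from compound 1 to compound 3 shows that the fluoro on the fused ring matters to the read-out, while the step from compound 2 to compound 3 concerns the chlorophenyl on an amine nitrogen in a ring. Going by the values given here, no measured pair adds a substituent to the fused ring, so the direction of the new step is open. The expectation for compound 4 in this assay is therefore a small step, a 1.1-fold lower number from compound 1 to compound 4 (0.03 log units; within the scatter), within or near the scatter. Compound 4 is estimated at 200 nM, with a range from 60 nM to 700 nM.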

Compound 4, inhibition constant: 191 nM
Compound 4: the middle estimate sits 1.0-fold (0.02 log units) above what was measured; measured number inside the range.
By their numbers in this assay, from the lowest: compound 2; then compound 3; then compounds 4 and 1 (each within the scatter of the next).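

In this assay, the step for chloro in place of hydrogen on the aromatic carbon ortho to a fluoro group is a 1.1-fold lower number from compound 1 to compound 4 (0.05 log units; within the scatter), so compound 4 and compound 1 cannot be told apart and this carbon of the shared core takes a chloro group without a readable change in the number. Going by these compounds alone, this is the first view of a substituent added at this carbon, and it contrasts with the loss of the fluoro group from the same ring, where a 2.3-fold lower number from compound 1 to compound 3 (0.36 log units; beyond the scatter) lies beyond the scatter, so on this ring one change moves the number and the other does not. Nothing available bears on why the added chloro leaves the number where it stands.

From the compounds shown here alone, whether a methoxy group or an amine on this carbon would leave the number just as unmoved remains open. Going by these compounds, it is also open whether chloro here would behave the same way without the fluoro group, or alongside the 3-chlorophenyl group of compound 2 in place of the 4-chlorophenyl group.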